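The source may hold more compounds than are shown below. What is called first, only, known or untested is meant among the compounds shown, and "the series" means these compounds.

Compound 1 `Cc1nc(S(C)(=O)=O)ccc1Oc1ncnc(OC2CCN(C(=O)OC(C)(C)C#N)CC2)c1F` is one of three carbamates sharing a core and differing only in the group attached through the oxygen of the carbonyl. In a functional assay on isolated protein for inhibition of Glucose-dependent insulinotropic receptor (Homo sapiens), read by HTRF and cAMP accumulation (a lower number here means that less compound is needed, a higher number that more compound is needed for the effect), compound 1 gives 92.9 nM, the highest of the three numbers. Compound 2 `Cc1nc(S(C)(=O)=O)ccc1Oc1ncnc(OC2CCN(C(=O)O[C@@H](C)C(F)(F)F)CC2)c1F` gives 9.86 nM in this assay, and compound 3 `Cc1nc(S(C)(=O)=O)ccc1Oc1ncnc(OC2CCN(C(=O)OC3(C(F)(F)F)COC3)CC2)c1F` gives 29.3 nM. The steps show a 9.4-fold lower number from compound 1 to compound 2 (0.97 log units; beyond the scatter) and a 3.2-fold lower number from compound 1 to compound 3 (0.50 log units; beyond the scatter), while between the two fluorinated analogues there is a 3.0-fold higher number from compound 2 to compound 3 (0.47 log units; beyond the scatter).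

Compound 4 `Cc1nc(S(C)(=O)=O)ccc1Oc1ncnc(OC2CCN(C(=O)SC3CCC3)CC2)c1F` takes a different route from compound 1: cyclobutylsulfanyl in place of 1-cyano-1-methylethoxy on a carbonyl carbon. Within the data shown here, no measured step exchanges the oxygen of the carbamate for sulfur, so nothing bears directly on this change. What the measured steps do show is that removing the 1-cyano-1-methylethyl group has twice lowered the number in this assay, by a modest amount each time. On that basis compound 4 is expected to land somewhat below compound 1, with a 2.3-fold lower number from compound 1 to compound 4 (0.37 log units; beyond the scatter) as the estimated step, though with wide uncertainty. The estimate for compound 4 in this assay is 40 nM, within a range from 12 nM to 130 nM.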

Compound 4, half-maximal effective concentration: 8.51 nM
The estimate for compound 4 lay 4.7-fold (0.67 log units) above the measured number; measured number below the stated range.
By their numbers in this assay, from the lowest: compounds 4 and 2 (each within the scatter of the next); then compound 3; then compound 1.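

In this assay, among these compounds, the carbonyl carbon tolerates a group attached through sulfur, and cyclobutylsulfanyl in place of 1-cyano-1-methylethoxy gives an 11-fold lower number from compound 1 to compound 4 (1.04 log units; beyond the scatter) and so the first step at this place printed as large. The same group gives a 3.4-fold lower number from compound 3 to compound 4 (0.54 log units; beyond the scatter) and a 1.2-fold lower number from compound 2 to compound 4 (0.06 log units; within the scatter) so compound 4 stands level with compound 2, showing that a four-membered ring of carbon only, attached through sulfur, can match the 1-(trifluoromethyl)ethoxy group here. No evidence is available on why this exchange has this effect.

Compound 4 changes both the linking atom and the group it carries, so the compounds shown leave open how much of the step belongs to sulfur and how much to the cyclobutyl ring. Cyclobutyloxy or cyclobutylamino on the same carbonyl carbon would separate the two.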